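The compounds below may be only part of what the source reports. "The series", "measured", "known", "first", "only" and "open" are said of these compounds alone.

Compound 1 `CCCCCCCCCCc1c(C)c(N(C)C)nc(C)c1O` and compound 2 `CCCCCCCCCCc1nc(N(C)C)c(C)c(C)c1O` share the same atoms joined differently; the difference between the two cores is not broken down here. In a functional assay on cells (Lymphocyte, Homo sapiens), read by trypan blue exclusion, with a stated time of 16 h, tested at 0.1 uM (a lower number here means a weaker effect, a higher number a stronger effect of the compound at the concentration tested), compound 1 gives 19%, while compound 2 gives 6%. Compound 3 `CCCCCCCCCCCCCCCCCCCc1c(C)c(N(C)C)nc(C)c1O` carries a longer chain than compound 1, the change being (nonyl in place of hydrogen on a saturated chain carbon, ten or more bonds along the chain from an aromatic carbon); in this assay compound 3 gives 8%, so the step is a number 11 percentage points lower from compound 1 to compound 3 (beyond the scatter). Compound 4 `CCCCCCCCCCCCCCCCCCCc1nc(N(C)C)c(C)c(C)c1O` bears the same kind of change on the core of compound 2, namely (nonyl in place of hydrogen on a saturated chain carbon, ten or more bonds along the chain from an aromatic carbon). Because compound 2 already gives 6%, little room remains for a downward step of the size seen from compound 1 to compound 3, so a smaller step is expected, a number 3 percentage points lower from compound 2 to compound 4 (within the scatter). Compound 4 is therefore expected to give about 3%, between 0% and 12%.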

Compound 4, a percentage reported as activity, at one concentration (the size of the read-out at that concentration, not a potency): 4%
Compound 4: middle estimate off by 1 percentage points, on the low side; the range from low to high includes it.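

On the core of compound 2, the same change gives a number 2 percentage points lower from compound 2 to compound 4 (within the scatter) in this assay. The two steps cannot be told apart, so the change looks similar on both cores as far as these compounds go: the same change on two cores in this assay, a number 11 percentage points lower (beyond the scatter) from compound 1 to compound 3 and a number 2 percentage points lower (within the scatter) from compound 2 to compound 4, 9 percentage points apart, within the scatter of two such steps This does not prove that the step carries over unchanged, since it rests on just two pairs at one concentration, and compound 2 already gives 6%, which leaves little room for a large downward step.

From the compounds shown here alone, it remains open how a chain of intermediate length, such as tetradecyl, would behave on either core. The same holds for a chain ending in an amine or a carboxylic acid.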